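A few compounds are considered here, and "the series" means these few. Any claim that something is new, unique, unknown or untested is made for them only; others in the source may bear on it.

Measured compounds in this study:
compound 1 `NC1=NC2(CCCCC2)N(c2ccccc2)C(N)=N1` — in an assay for inhibition of Dihydrofolate reductase (Bos taurus), using NADPH (on this read-out lower numbers stand for stronger inhibition and higher numbers for weaker inhibition), compound 1 gives only a limit, > 100000 nM
compound 2 `NC1=NC2(CCCCC2)N(c2ccc(Cl)cc2)C(N)=N1` — in this assay compound 2 gives only a limit, > 100000 nM
compound 3 `Cc1ccccc1N1C(N)=NC(N)=NC12CCCCC2` — in this assay compound 3 gives only a limit, > 100000 nM

Compound 1 therefore stands at a limit of this assay, and no number places it against the other two compounds. Compound 4 `COc1cccc(N2C(N)=NC(N)=NC23CCCCC3)c1` differs from compound 1 by methoxy in place of hydrogen on an aromatic carbon. The measured steps that bear on this change are a step that the two limits leave unreadable from compound 1 to compound 2 and a step that the two limits leave unreadable from compound 1 to compound 3; neither has a readable size because of the limit of > 100000 nM in this assay, at which 3 of the 3 values shown sit. Within the data shown here, no measured step thus fixes a direction or a size for the change to compound 4. Compound 4 is expected to stay at the limit as well, so the expected step is a step that the limit leaves unreadable from compound 1 to compound 4. The estimate for compound 4 is 150000 nM, within a range from 30000 nM to 1000000 nM.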

Compound 4, half-maximal inhibitory concentration: > 100000 nM
Compound 4 gave a limit, no number; the forecaster's own chance of this, stated with the estimate: 85%; the middle value is on the limit's open side.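

No size can be read for the step from compound 1 to compound 4, because both compounds give only a limit in this assay: the limit of > 100000 nM in this assay, at which 4 of the 4 values shown sit.

The compounds shown leave open how strongly any of them inhibits, and whether any of these changes shifts that inhibition.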